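This account rests on a few compounds, and the source may have more. Where it says the series, first, only, none or still open, it means among the compounds named here.

Of the compounds shown here, three have been measured in a functional assay on PC-3 cells (Homo sapiens) for inhibition; on this read-out lower numbers stand for stronger inhibition and higher numbers for weaker inhibition. Compound 3 `COc1cc2nc(N3CCN(S(=O)(=O)c4ccc(Cl)s4)CC3)nc(N)c2cc1OC` gives 25000 nM. Among the measured compounds shown here, compound 2 `COc1cc2nc(N3CCN(C(=O)c4ccc(C(C)(C)C)cc4)CC3)nc(N)c2cc1OC` gives 47000 nM, a number that lies within the usual scatter of the one for compound 3. For the measured compounds named here, compound 1 `COc1ccc(C(=O)N2CCN(c3nc(N)c4cc(OC)c(OC)cc4n3)CC2)cc1OC` gives 71000 nM, a number that lies beyond the scatter from the one for compound 3, so compound 3 stands at the strong end of this small set, with compound 2 close beside it. Going by the values given here, the only single change between measured compounds, a 1.5-fold lower number from compound 1 to compound 2 (0.18 log units; within the scatter), swapped one aromatic group for another on a carbonyl carbon and stayed within the scatter.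

Compound 4 `COc1cc2nc(N3CCN(S(=O)(=O)c4ccc(OC(F)(F)F)cc4)CC3)nc(N)c2cc1OC` differs from compound 3 in one place: 4-(trifluoromethoxy)phenyl in place of 5-chlorothiophen-2-yl on a sulfonyl sulfur. This is again a swap of one aromatic group for another on the same kind of position, though here on a sulfonyl sulfur rather than a carbonyl carbon. Among the compounds with values here, the one comparable step gave no movement beyond the scatter, so the expected step is no change at the digits printed from compound 3 to compound 4 (within the scatter), a change that may fall either way but is expected to stay within the scatter. Compound 4 is therefore estimated at 25000 nM, with a range from 8000 nM to 80000 nM.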

Compound 4, half-maximal inhibitory concentration: 25000 nM
Compound 4: middle estimate and measured number agree at the digits printed; the range from low to high includes it.
By their numbers in this assay, from the lowest: compounds 3, 4, 2 and 1 (each within the scatter of the next, the first and the last beyond it).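

In this assay, the swap on the sulfonyl sulfur gives no change at the digits printed from compound 3 to compound 4 (within the scatter). This step replaces a five-membered aromatic ring with 1 hetero atom, 6 heavy atoms in all, with a six-membered aromatic ring of carbon only, 11 heavy atoms in all, so a clear change in ring type and size leaves the number where it was. The earlier step covered only a carbonyl carbon, and together the two steps show aromatic swaps at both kinds of attachment staying within the scatter, though the data offer no explanation for this.

Among the compounds shown here, all the groups at this position so far are aromatic, so the effect of a non-aromatic group, such as a longer carbon chain, an amine or a carboxylic acid, remains open. The compounds shown also leave open how the carbonyl and sulfonyl links compare with the same aromatic group attached.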